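Shortening the Chain: Aldehyde in Place of Acid

The source may hold more compounds than are shown below. What is called first, only, known or untested is meant among the compounds shown, and "the series" means these compounds.

Three compounds share one core and differ only in the chain attached to it. Compound 1 `COc1cccc(Sc2c(NS(=O)(=O)c3ccc(C(C)(C)C)cc3)noc2CCCC#N)c1` carries a 2-cyanoethyl group on that chain, compound 2 `COc1cccc(Sc2c(NS(=O)(=O)c3ccc(C(C)(C)C)cc3)noc2CO)c1` a hydroxy group, and compound 3 `COc1cccc(Sc2c(NS(=O)(=O)c3ccc(C(C)(C)C)cc3)noc2CCCC(=O)O)c1` a 2-carboxyethyl group. In an assay on COS-7 cells for displacement of a labelled ligand from Endothelin receptor type B (Sus scrofa) (a lower number here means a stronger inhibitor, a higher number a weaker inhibitor), compound 1 gives 520 nM, compound 2 gives 560 nM, and compound 3 gives 500 nM.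

Compound 3 has the lowest of the three numbers, yet the step of a 1.0-fold lower number from compound 1 to compound 3 (0.02 log units; within the scatter) and the step of a 1.1-fold lower number from compound 2 to compound 3 (0.05 log units; within the scatter) both lie within the scatter, so the three compounds cannot be told apart on these data. The step of a 1.1-fold higher number from compound 1 to compound 2 (0.03 log units; within the scatter) likewise lies within the scatter.

Compound 4 `COc1cccc(Sc2c(NS(=O)(=O)c3ccc(C(C)(C)C)cc3)noc2CCC=O)c1` has not yet been measured. It differs from compound 3 by formyl in place of carboxymethyl on a saturated chain carbon, two bonds along the chain from an aromatic carbon. Every measured change to this chain, whether in its length or in the group at its end, left the number where it was, and these three steps are the ones that bear on the new change, which again alters both the length of the chain and the group at its end. A step of no size beyond the scatter is therefore expected, a 1.0-fold higher number from compound 3 to compound 4 (0.02 log units; within the scatter). Compound 4 is estimated to give 520 nM in this assay, with a range from 250 nM to 1100 nM.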

Compound 4, half-maximal inhibitory concentration: 500 nM
Estimate against measurement, compound 4: 1.0-fold (0.02 log units) above, within the range that was stated.
By their numbers in this assay, from the lowest: compounds 3, 4, 1 and 2 (each within the scatter of the next).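

In this assay, formyl in place of carboxymethyl gives no change at the digits printed from compound 3 to compound 4 (within the scatter), so an end group with no hydrogen-bond donor, on a chain shorter than that of compound 3, still falls within the scatter of the acid. The other two comparisons agree, with a 1.1-fold lower number from compound 2 to compound 4 (0.05 log units; within the scatter) and a 1.0-fold lower number from compound 1 to compound 4 (0.02 log units; within the scatter), which means that a fourth end group and a third chain length join the set without separating any compound from the rest, and hydroxy, nitrile, carboxy and formyl ends all remain indistinguishable at this position. No measurement is available here that could explain this flat result.

The compounds shown leave open whether this tolerance extends to an amine or a primary amide at the end of the chain, or to a chain much longer than the one in compound 3. They also leave open whether the chain matters at all, which a plain methyl group in its place would begin to test.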